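The source may report more compounds than this note shows. Statements on the series, on what has been measured and on what is new or still open speak of the compounds shown alone.

Values in a functional assay on MDA-MB-435 cells (Homo sapiens) for inhibition, read by sulforhodamine B assay, with a stated time of 48 h (on this read-out higher numbers stand for weaker inhibition of growth and lower numbers for stronger inhibition of growth), for the three measured members of the series:

compound 1, `COc1cc(-c2nn(-c3cccc(NC(=O)c4cccc(C(F)(F)F)c4)c3)cc2-c2ccncc2)ccc1Cl`: 705 nM
compound 2, `COc1cc(-c2nn(-c3cccc(NC(=O)Nc4cccc(C(F)(F)F)c4)c3)cc2-c2ccncc2)ccc1Cl`: 866 nM
compound 3, `COc1cc(-c2nn(-c3cccc(NC(=O)c4ccc(Cl)c(C(F)(F)F)c4)c3)cc2-c2ccncc2)ccc1Cl`: 664 nM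

Compound 3 carries the lowest of the three numbers, but its separation from the others is small: a 1.1-fold lower number from compound 1 to compound 3 (0.03 log units; within the scatter) and a 1.3-fold lower number from compound 2 to compound 3 (0.12 log units; within the scatter) both sit inside the scatter, so the three compounds cannot be ranked against each other on these data.

Compound 4, `COc1cc(-c2nn(-c3cccc(NC(=O)Nc4ccc(Cl)c(C(F)(F)F)c4)c3)cc2-c2ccncc2)ccc1Cl`, has not been measured. It differs from compound 3 in one place: (4-chloro-3-(trifluoromethyl)phenyl)amino in place of 4-chloro-3-(trifluoromethyl)phenyl on a carbonyl carbon. The same exchange of a carbonyl-borne aryl for an arylamino has been run once already, from compound 1 to compound 2, where the carbonyl carries the 3-(trifluoromethyl)phenyl group without the chloro: a 1.2-fold higher number from compound 1 to compound 2 (0.09 log units; within the scatter). The chloro itself, from compound 1 to compound 3, also moved nothing beyond the scatter: a 1.1-fold lower number from compound 1 to compound 3 (0.03 log units; within the scatter). The composite step a 1.3-fold lower number from compound 2 to compound 3 (0.12 log units; within the scatter) likewise stays inside the scatter.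

The expectation for compound 4 in this assay is therefore a number close to that of compound 3, with at most a small rise of the kind seen from compound 1 to compound 2, i.e. an expected step of a 1.2-fold higher number from compound 3 to compound 4 (0.08 log units; within the scatter) that lies within the scatter. The estimate for compound 4 is 800 nM, with a range from 400 nM to 1600 nM.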

Compound 4, concentration for 50% growth inhibition: 683 nM
For compound 4 the middle estimate is 1.2-fold (0.07 log units) above the measured one; the range from low to high includes it.
By their numbers in this assay, from the lowest: compounds 3, 4, 1 and 2 (each within the scatter of the next).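

In this assay the exchange of a carbonyl-borne aryl for an arylamino has now been read with the chloro present, and the step of a 1.0-fold higher number from compound 3 to compound 4 (0.01 log units; within the scatter) stays inside the scatter, as the earlier step without the chloro did. Read as a single replacement on the carbonyl carbon, the step of a 1.0-fold lower number from compound 1 to compound 4 (0.01 log units; within the scatter) also stays inside the scatter, so neither the arylamino exchange nor the chloro, alone or together, separates any of the four compounds. The chloro has now been read on both sides of that exchange, the second time as the step of a 1.3-fold lower number from compound 2 to compound 4 (0.10 log units; within the scatter) on the arylamino side, and the two readings agree: the same change on two cores in this assay, a 1.1-fold lower number (0.03 log units; within the scatter) from compound 1 to compound 3 and a 1.3-fold lower number (0.10 log units; within the scatter) from compound 2 to compound 4, 1.2-fold (0.08 log units) apart, within the scatter of two such steps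

All four compounds keep the trifluoromethyl group and the shared core, and every exchange read so far is confined to the arylamide or arylamino end of the molecule. As far as these compounds go, whether this position can give a step beyond the scatter stays open, for instance with a nitrile or a methoxy in place of the trifluoromethyl, or with a chain ending in an amine or a carboxylic acid on the aryl ring.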